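This account rests on a few compounds, and the source may have more. Where it says the series, first, only, none or still open, it means among the compounds named here.

Of the compounds shown here, three built on one shared core have been tested in a functional assay on SK-MEL-28 cells (Homo sapiens) for cytotoxicity, read by MTT assay, with a stated time of 3 days; a higher number here means a weaker inhibitor, a lower number a stronger inhibitor. Compound 1 `N#Cc1c(Cl)nc(SCc2nc3ccccc3[nH]2)nc1-c1ccccc1` gives 3.28 nM. Compound 2 `N#Cc1c(Nc2ccccc2)nc(SCc2nc3ccccc3[nH]2)nc1-c1ccccc1` gives 8.9 nM, and compound 3 `N#Cc1c(NC(N)=S)nc(SCc2nc3ccccc3[nH]2)nc1-c1ccccc1` gives 4.8 nM. Compound 2 thus holds the highest number of the three: the step of a 2.7-fold higher number from compound 1 to compound 2 (0.43 log units; beyond the scatter) lies beyond the scatter, whereas the step of a 1.9-fold lower number from compound 2 to compound 3 (0.27 log units; within the scatter) stays within it, as does the step of a 1.5-fold higher number from compound 1 to compound 3 (0.17 log units; within the scatter).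

Compound 4 `CN1CCN(c2nc(SCc3nc4ccccc4[nH]3)nc(-c3ccccc3)c2C#N)CC1` has not yet been measured. Against compound 2 the change is 4-methylpiperazin-1-yl in place of anilino on an aromatic carbon. Going by the values given here, two measured steps touch the same position. The step of a 2.7-fold higher number from compound 1 to compound 2 (0.43 log units; beyond the scatter) showed that placing an anilino group there raised the number modestly, and the step of a 1.9-fold lower number from compound 2 to compound 3 (0.27 log units; within the scatter) showed that exchanging the anilino group for a smaller group on that carbon brought the number back down, though only within the scatter. Among the compounds with values here, compound 4 keeps a group of matching size at that carbon but exchanges the aromatic ring for a non-aromatic ring with two hetero atoms, and no measured step covers such an exchange. For compound 4 the expected step in this assay is therefore small, a 1.5-fold lower number from compound 2 to compound 4 (0.17 log units; within the scatter), leaning toward a lower number. Compound 4 is expected to give about 6 nM, within 2.5 nM to 15 nM.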

Compound 4, half-maximal inhibitory concentration: 20 nM
Beside the measured number, compound 4's estimate is 3.3-fold (0.52 log units) below it; measured number outside the range, above it.
By their numbers in this assay, from the lowest: compounds 1, 3 and 2 (each within the scatter of the next, the first and the last beyond it); then compound 4.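

In this assay anilino and 4-methylpiperazin-1-yl carry the same count of heavy atoms, yet the exchange gives a 2.2-fold higher number from compound 2 to compound 4 (0.35 log units; beyond the scatter) and so a matching count at this aromatic carbon did not keep the number level. Compound 4 is the weakest inhibitor of the four, with a 4.2-fold higher number from compound 3 to compound 4 (0.62 log units; beyond the scatter) and a 6.1-fold higher number from compound 1 to compound 4 (0.79 log units; beyond the scatter) as the two largest steps in the series, which widens the spread at this position beyond what compounds 1, 2 and 3 had shown. Nothing in the data given here accounts for this rise.

The exchange changes several things at once: the aromatic ring gives way to a non-aromatic ring with 2 hetero atoms, the hydrogen-bond donor count falls from 1 to 0, and the acceptor count rises from 1 to 2, so these compounds cannot say which of these changes goes with the higher number. As far as these compounds go, a cyclohexylamino group would keep the nitrogen-bound hydrogen on a non-aromatic ring, while a morpholin-4-yl or an unmethylated piperazin-1-yl group would vary the far end of the ring, and the numbers for such groups remain open.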